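Methyl for methoxy on the aryl of compound 2

A few compounds are considered here, and "the series" means these few. Any claim that something is new, unique, unknown or untested is made for them only; others in the source may bear on it.

Compound 1 `Cc1ccc(-c2cn3nc(Cc4ccc(Cl)cc4)sc3n2)cc1` sits at the limit of > 250000 nM in a functional assay on HeLa cells (Homo sapiens) for cytotoxicity, with a stated time of 72 h (a lower number here means a stronger inhibitor, a higher number a weaker inhibitor), and that entry is a limit of the assay, not a number. Among the measured compounds shown here, compound 2 `COc1ccc(-c2nc3sc(Cc4ccc(Cl)cc4)nn3c2C=O)cc1` gives 6000 nM in this assay and so holds the only number in the set; the remaining entry is the limit of > 250000 nM in this assay, at which 1 of the 2 values shown sits. Compound 3 `Cc1ccc(-c2nc3sc(Cc4ccc(Cl)cc4)nn3c2C=O)cc1` is not yet measured in this assay. It differs from compound 2 in one place: methyl in place of methoxy on an aromatic carbon, or 4-methoxyphenyl to 4-methylphenyl when the difference is cut one bond further out. For the measured compounds named here, no step between two measured compounds covers this change, so the expectation rests on compound 2 alone. The expected step of a 1.7-fold higher number from compound 2 to compound 3 (0.22 log units; within the scatter) is small, a slight weakening or none beyond the scatter. For compound 3 the estimated value in this assay is 10000 nM, with a range from 3000 nM to 40000 nM.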

Compound 3, half-maximal inhibitory concentration: 21000 nM
Estimate against measurement, compound 3: 2.1-fold (0.32 log units) below, within the range that was stated.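

In this assay, the step for methyl in place of methoxy on an aromatic carbon is a 3.5-fold higher number from compound 2 to compound 3 (0.54 log units; beyond the scatter), so this position responds to the change and the lower number stays with methoxy. With the 4-methylphenyl group held in place, the step for formyl in place of hydrogen on an aromatic carbon is an at least 11-fold lower number from compound 1 to compound 3 (1.07 log units; beyond the scatter), which gives the series a one-place reading of the formyl group. The entry for compound 1 is a limit of the assay, not a number: the limit of > 250000 nM in this assay, at which 1 of the 3 values shown sits.

From the compounds shown here alone, the formyl step is read only with the 4-methylphenyl group in place, so its size with the 4-methoxyphenyl group stays open. Also open, going by these compounds, is how hydroxymethyl or a carboxylic acid in place of formyl, or an amine or chlorine in place of methoxy, would read in this assay.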